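The source may report more compounds than this note shows. Statements on the series, on what has been measured and on what is new or still open speak of the compounds shown alone.

Working notes on the series. Among the compounds with values here, in a functional assay on SH-SY5Y cells (Homo sapiens) for cytotoxicity, read by MTT assay, with a stated time of 48 h (a higher number here means a weaker inhibitor, a lower number a stronger inhibitor), compound 1 `COc1cc(/C=C/C(=O)/C=C/c2nc3cc(C)ccc3n2C)ccc1O` gives 4700 nM and compound 2 `COc1cc(/C=C/C(=O)/C=C/c2nc3cc([N+](=O)[O-])ccc3n2C)ccc1O` gives 4600 nM, so compound 2 stands within the scatter of the only other measured compound. Within the data shown here, the single measured step, a 1.0-fold lower number from compound 1 to compound 2 (0.01 log units; within the scatter), is nitro in place of methyl on an aromatic carbon. Compound 3 `COc1ccc(/C=C/C(=O)/C=C/c2nc3cc([N+](=O)[O-])ccc3n2C)cc1O` has the same atoms as compound 2, joined differently: 3-hydroxy-4-methoxyphenyl in place of 4-hydroxy-3-methoxyphenyl on a double-bonded chain carbon bound to a double-bonded chain carbon. Among the measured compounds shown here, no measured step changes this group, so the evidence is indirect: the one available step, a 1.0-fold lower number from compound 1 to compound 2 (0.01 log units; within the scatter), changes another part of the shared core and stays within the scatter. No direction can be argued from the data, and no shift beyond the scatter is expected in this assay. The expected change is a 1.1-fold higher number from compound 2 to compound 3 (0.04 log units; within the scatter). For compound 3 the estimated value is 5000 nM, with an expected range of 2200 nM to 11000 nM.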

Compound 3, half-maximal inhibitory concentration: 8100 nM
For compound 3 the middle estimate is 1.6-fold (0.21 log units) below the measured one; measured number inside the range.
By their numbers in this assay, from the lowest: compounds 2, 1 and 3 (each within the scatter of the next).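

Within the data shown here, the exchange of 4-hydroxy-3-methoxyphenyl for 3-hydroxy-4-methoxyphenyl on a double-bonded chain carbon bound to a double-bonded chain carbon is the only measured change at this position, and in this assay it gives a 1.8-fold higher number from compound 2 to compound 3 (0.25 log units; within the scatter). The two groups match in heavy atoms, hydrogen-bond donors and acceptors, and on the core of compound 2 this exchange of hydroxy and methoxy places leaves the number within the scatter. Nothing available bears on a cause for this step.

From the compounds shown here alone, whether the same exchange reads alike on the core of compound 1, with methyl where compound 2 has nitro, remains open. Also open, going by these compounds, is how an amine or a carboxylic acid in place of the hydroxy of 4-hydroxy-3-methoxyphenyl would read in this assay, and whether any change at this position moves the number beyond the scatter.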